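A few compounds are considered here, and "the series" means these few. Any claim that something is new, unique, unknown or untested is made for them only; others in the source may bear on it.

Measured compounds:
- compound 1, `CN(c1ccc2[nH]c(-c3n[nH]c4ccccc34)cc2n1)S(=O)(=O)c1ccccc1`: 14000 nM
- compound 2, `CN(c1ccc2[nH]c(-c3n[nH]c4ccccc34)cc2n1)S(=O)(=O)c1ccc(Cl)cc1`: 18200 nM
- compound 3, `COc1ccc(S(=O)(=O)N(C)c2ccc3[nH]c(-c4n[nH]c5ccccc45)cc3n2)cc1`: 24300 nM

All three share one core and differ only in the group on the sulfonyl-bearing ring. In a functional assay on A549 cells (Homo sapiens) for antiproliferative activity, read by MTT assay, with a stated time of 72 h (a higher number here means a weaker inhibitor, a lower number a stronger inhibitor), compound 1 gives 14000 nM, compound 2 gives 18200 nM, and compound 3 gives 24300 nM. Compound 3 has the highest number of the three, but the steps to it are small: a 1.7-fold higher number from compound 1 to compound 3 (0.24 log units; within the scatter) and a 1.3-fold higher number from compound 2 to compound 3 (0.13 log units; within the scatter). Since both lie within the scatter, the three compounds cannot be told apart on these numbers.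

Compound 4, `COc1ccc(S(=O)(=O)N(C)c2ccc3[nH]c(-c4n[nH]c5ccccc45)cc3n2)c(OC)c1`, differs from compound 3 by methoxy in place of hydrogen on an aromatic carbon. For the measured compounds named here, the steps that bear on this are the ones in which a small group is placed on that same ring: a 1.3-fold higher number from compound 1 to compound 2 (0.11 log units; within the scatter) and a 1.7-fold higher number from compound 1 to compound 3 (0.24 log units; within the scatter). Each of them stayed within the scatter, and the exchange a 1.3-fold higher number from compound 2 to compound 3 (0.13 log units; within the scatter) did likewise. Going by the values given here, the closest precedent, a methoxy added to that ring in going from compound 1 to compound 3, left the number essentially unchanged. A second methoxy is therefore expected to do no more than that.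

Compound 4 is thus expected to give 28000 nM, with a range from 14000 nM to 56000 nM. This estimate means a step of a 1.2-fold higher number from compound 3 to compound 4 (0.06 log units; within the scatter), which is expected to stay within the scatter.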

Compound 4, half-maximal inhibitory concentration: 25900 nM
For compound 4 the middle estimate is 1.1-fold (0.03 log units) above the measured one, within the range that was stated.
By their numbers in this assay, from the lowest: compounds 1, 2, 3 and 4 (each within the scatter of the next).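

In this assay, compound 4 is the first of these compounds to carry two groups on the sulfonyl-bearing ring, and the added methoxy, ortho to a large group and meta to a methoxy group, has no readable effect: a 1.1-fold higher number from compound 3 to compound 4 (0.03 log units; within the scatter) stays small. The wider comparisons tell the same story, since a 1.4-fold higher number from compound 2 to compound 4 (0.15 log units; within the scatter) and a 1.9-fold higher number from compound 1 to compound 4 (0.27 log units; within the scatter) both remain within the scatter, so neither 4-chlorophenyl nor unsubstituted phenyl can be told apart from 2,4-dimethoxyphenyl on these numbers. Nothing measured here offers an explanation for this result.

What the compounds shown leave open is whether any group at this position can move the number beyond the scatter, as they cover only hydrogen, chloro and methoxy on this ring, and not, for example, an amine, a carboxylic acid or a longer chain. They also leave open what happens when the shared core or the methyl group on the sulfonamide nitrogen is changed, since these stay the same in all four compounds.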